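Removing the acetyl from the side chain of compound 2

The source may report more compounds than this note shows. Statements on the series, on what has been measured and on what is new or still open speak of the compounds shown alone.

Measured compounds:
compound 1, `CC(=O)OC(C)n1cnc2c(Cl)nc(N)nc21`: > 500000 nM
compound 2, `CC(=O)OC(C)n1cnc2c(Cl)nc(I)nc21`: 3550 nM

In a functional assay on SW-620 cells (Homo sapiens) for inhibition (a higher number here means a weaker inhibitor, a lower number a stronger inhibitor), compound 2 gives 3550 nM. For compound 1 this assay reports only a limit, > 500000 nM, which is the limit of > 500000 nM in this assay, at which 1 of the 2 values shown sits. Among the measured compounds shown here, compound 2 therefore holds the only number in the set; its companion value is a limit, so no ordering beyond that can be stated. For the measured compounds named here, the single measured step, an at least 140-fold lower number from compound 1 to compound 2 (2.14 log units; beyond the scatter), changes the aromatic carbon and tells nothing about the side chain on the nitrogen.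

Compound 3, `CC(O)n1cnc2c(Cl)nc(I)nc21`, differs from compound 2 by hydrogen in place of acetyl on an oxygen on a saturated carbon. Going by the values given here, no measured step touches this oxygen, so there is no evidence on which to anchor a direction for the step. In the absence of any comparable step, the working expectation for compound 3 in this assay is a number near that of compound 2, with wide uncertainty in both directions. The expected step is a 1.7-fold higher number from compound 2 to compound 3 (0.23 log units; within the scatter), estimated as lying within or only modestly beyond the scatter. For compound 3 the estimate is 6000 nM, with a range from 1500 nM to 30000 nM.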

Compound 3, half-maximal inhibitory concentration: > 500000 nM
Compound 3: only a limit was reported; the forecaster's own chance of this, stated with the estimate: 10%; middle value at least 83-fold (1.92 log units) away from the limit.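

In this assay, the change from acetoxy to hydroxy gives an at least 140-fold higher number from compound 2 to compound 3 (2.14 log units; beyond the scatter), and the reading for compound 3 is a limit, not a number. Among the compounds shown here, until now only the aromatic carbon had been seen to move the read-out, so this is the first sign that the side chain oxygen matters as well, and the acetyl on it cannot be dropped without losing the measurable value. Of the three compounds, only compound 2, with iodo and acetyl together, gives a number, and a change at either place ends at the same ceiling: the limit of > 500000 nM in this assay, at which 2 of the 3 values shown sit.

Going by these compounds, both steps out of compound 2 end at a limit, so the true size of each remains unknown. On these data alone, it also remains open whether the acetyl itself counts or whether another group on that oxygen would serve, and a methyl ether, a propionyl ester or a benzoyl ester there would separate these readings, as would bromo in place of iodo on the aromatic carbon.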